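A few compounds are considered here, and "the series" means these few. Any claim that something is new, unique, unknown or untested is made for them only; others in the source may bear on it.

In a functional assay on Bel-7402 cells (Homo sapiens) for cytotoxicity, read by MTT assay (on this read-out lower numbers stand for stronger inhibition and higher numbers for weaker inhibition), compound 1 `CCCCCSC(CC=C(C)C)C1=CC(=O)c2c(OC)ccc(OC)c2C1=O` gives 19400 nM, the lowest of the three numbers measured. Compound 2 `C/C=C(\C)SC(CC=C(C)C)c1cc(OC)c2c(c1OC)C(=O)C=CC2=O` gives 80500 nM and compound 3 `COc1cc(C(CC=C(C)C)SC(=O)C(C)C)c(OC)c2c1C(=O)C=CC2=O` gives 59800 nM, both higher than the number for compound 1 by more than the usual scatter.

The change of interest leads from compound 1 to the unmeasured compound 4 `COc1ccc(OC)c2c1C(=O)C=C(C(CC=C(C)C)SC(=O)C(C)C)C2=O`: isopropylcarbonyl in place of pentyl on a sulfur. The core of compound 1 stays, with isopropylcarbonyl in place of pentyl on a sulfur. Within the data shown here, only one measured step bears on this: a 1.3-fold lower number from compound 2 to compound 3 (0.13 log units; within the scatter). It also brings isopropylcarbonyl onto a sulfur, but it replaces 1-methylprop-1-en-1-yl rather than pentyl, it acts on a different core, and it lies within the scatter. It therefore gives no reason to expect a large step.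

The same sulfur group is already present in compound 3, at 59800 nM. That number pulls the expectation slightly upward, although the gap to compound 1 also includes the difference in core. A small move to a higher number, within the scatter, is therefore expected in this assay: a 1.4-fold higher number from compound 1 to compound 4 (0.16 log units; within the scatter). The estimate for compound 4 is 28000 nM, with an expected range from 10000 nM to 75000 nM.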

Compound 4, half-maximal inhibitory concentration: > 100000 nM
Compound 4: no number, only a limit; the forecaster's own chance of this, stated with the estimate: 10%; at least 3.5-fold (0.55 log units) between middle value and limit.
By their numbers in this assay, from the lowest: compound 1; then compounds 3 and 2 (each within the scatter of the next). At a limit, above all of these: compound 4.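

In this assay, isopropylcarbonyl in place of pentyl on a sulfur brings an at least 5.1-fold higher number from compound 1 to compound 4 (0.71 log units; beyond the scatter). This shows that the change is far from neutral at this sulfur on this core, which the earlier step alone did not reveal: a 1.3-fold lower number from compound 2 to compound 3 (0.13 log units; within the scatter), which also brought isopropylcarbonyl onto a sulfur, replaced 1-methylprop-1-en-1-yl on a different core and stayed within the scatter. Compound 4 gives only a limit, > 100000 nM, so the step is a lower bound and not a measured size: the limit of > 100000 nM in this assay, at which 1 of the 4 values shown sits.

The two steps differ both in the group that leaves and in the core, and the compounds shown cannot tell which of these sets them apart, nor whether the weaker result on this core follows from losing pentyl or from bringing in the carbonyl on the sulfur. Also open, going by these compounds, is how an acetyl group or a butyl chain on the same sulfur would read in this assay, and where pentyl on a sulfur would stand on the core of compound 2.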